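The source may hold more compounds than are shown below. What is called first, only, known or untested is meant among the compounds shown, and "the series" means these compounds.

Working notes on the series, all values from a functional assay on HCT-116 cells (Homo sapiens) for antiproliferative activity, read by MTT assay, with a stated time of 72 h; on this read-out higher numbers stand for weaker inhibition and lower numbers for stronger inhibition. Compound 1 `NC1=NC2(CCSCC2)N(OCCCOc2ccc(Cl)c(Cl)c2)C(N)=N1` gives 1 nM, compound 2 `NC1=NC2(CCSCC2)N(OCCCOc2ccc(Br)cc2)C(N)=N1` gives 20 nM, and compound 3 `NC1=NC2(CCOCC2)N(OCCCOc2cccc(Cl)c2Cl)C(N)=N1` gives 5 nM. Compound 3 therefore holds the middle of the three numbers, clear of the scatter on both sides.

Compound 4 `Cc1cc(C)cc(OCCCON2C(N)=NC(N)=NC23CCOCC3)c1` keeps the core of compound 3 and differs only in the phenyl group: 3,5-dimethylphenyl in place of 2,3-dichlorophenyl on an oxygen on a saturated carbon. Among the compounds with values here, the one measured step that bears on this is a 20-fold higher number from compound 1 to compound 2 (1.30 log units; beyond the scatter). Within the data shown here, it is large and is also an exchange of the phenyl group on an oxygen on a saturated carbon, but it sits on the core of compound 1, and no measured step covers the dimethylphenyl group. A single step gives only a weak guide to direction, so a higher number of moderate size, smaller than that step, is expected in this assay. The estimated step is a 3.0-fold higher number from compound 3 to compound 4 (0.48 log units; beyond the scatter). The expected value for compound 4 is 15 nM, with an estimated range of 4 nM to 60 nM.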

Compound 4, half-maximal inhibitory concentration: 190 nM
Compound 4: middle estimate off by 13-fold (1.10 log units), on the low side, outside the stated range (above it).
By their numbers in this assay, from the lowest: compound 1; then compound 3; then compound 2; then compound 4.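

In this assay the exchange of 2,3-dichlorophenyl for 3,5-dimethylphenyl gives a 38-fold higher number from compound 3 to compound 4 (1.58 log units; beyond the scatter), so a large step at this place is no longer confined to the core of compound 1, where the earlier exchange gave a 20-fold higher number from compound 1 to compound 2 (1.30 log units; beyond the scatter). The two groups match in heavy-atom count and in hydrogen-bond donors and acceptors and differ in chlorine against carbon, so the number responds strongly to a change that leaves those counts untouched. No measurement at hand accounts for this step.

Open, going by these compounds, is whether the step follows the kind of group or where it sits on the ring, a question that 3,5-dichlorophenyl and 2,3-dimethylphenyl on the core of compound 3 would separate. Also open, on these data alone, is whether 3,5-dimethylphenyl behaves the same way on the core of compound 1.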